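Three Analogues at the Assay Ceiling, a Fourth Expected There

The source may hold more compounds than are shown below. What is called first, only, known or untested is meant among the compounds shown, and "the series" means these compounds.

Compound 1 `COCn1c(CC(O)(CO)CO)cc(=O)[nH]c1=O`: in a functional assay on MCF7 cells (Homo sapiens) for antiproliferative activity, read by MTT assay, with a stated time of 72 h (a lower number here means a stronger inhibitor, a higher number a weaker inhibitor), compound 1 gives > 100000 nM, which is a limit of the assay.
Compound 2 `C[Si](C)(C)CCOCn1c(CC(O)(CO)CO)cc(=O)[nH]c1=O`: in this assay compound 2 gives > 100000 nM, which is a limit of the assay.
Compound 3 `Cc1c(CC(O)COCc2ccccc2)n(COCC[Si](C)(C)C)c(=O)[nH]c1=O`: in this assay compound 3 gives > 100000 nM, which is a limit of the assay.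

Compound 1 differs from compound 2 by a hydrogen atom in place of a group of 5 heavy atoms (4 carbon, 1 silicon; no ring), on a saturated chain carbon bound to an oxygen on a saturated carbon. The step that the two limits leave unreadable from compound 2 to compound 1 has a size that two limits leave unreadable. Compound 4 `COCn1c(CC(O)COCc2ccccc2)c(C)c(=O)[nH]c1=O`, not yet measured, differs from compound 3 by a hydrogen atom in place of a group of 5 heavy atoms (4 carbon, 1 silicon; no ring), on a saturated chain carbon bound to an oxygen on a saturated carbon, and the place of the change is the same as in the pair above, so it is the same change. How the core of compound 3 differs from the core of compound 2 is not broken down here.

Compound 4 is expected to give 150000 nM in this assay because every measured value sits at the limit of > 100000 nM in this assay, at which 3 of the 3 values shown sit. The estimate for compound 4 is expected to span from 50000 nM to 600000 nM. The estimated step that the limit leaves unreadable from compound 3 to compound 4 is expected to stay unreadable, with a further limit the most likely outcome.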

Compound 4, half-maximal inhibitory concentration: > 100000 nM
Compound 4 ended at the assay's limit; the forecaster's own chance of this, stated with the estimate: 85%; the middle value lies beyond the limit too.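

No step can be read from compound 3 to compound 4, since both values are limits in this assay: the limit of > 100000 nM in this assay, at which 4 of the 4 values shown sit.

The compounds shown leave open how far any of the four lies beyond that limit, and whether replacing the group of 5 heavy atoms with hydrogen changes the antiproliferative activity at all.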